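Swapping piperidin-1-yl for benzyl on compound 3

A few compounds are considered here, and "the series" means these few. Any claim that something is new, unique, unknown or untested is made for them only; others in the source may bear on it.

compound 1 `Cc1cc(=O)c2c(O)cc(OCc3ccc([N+](=O)[O-])cc3)c([C@H]3CCN(C)C[C@H]3O)c2o1` gives 23%
compound 2 `Cc1cc(=O)c2c(O)cc(OC/C=C/c3ccccc3)c([C@H]3CCN(C)C[C@H]3O)c2o1` gives 18%
compound 3 `Cc1cc(=O)c2c(O)c(CN3CCC(N4CCCCC4)CC3)c(O)c([C@H]3CCN(C)C[C@H]3O)c2o1` gives 17%

In a functional assay on PC-3 cells (Homo sapiens) for inhibition, read by MTT assay, with a stated time of 48 h, tested at 10 uM (on this read-out higher numbers stand for more inhibition of growth at the one concentration tested and lower numbers for less inhibition of growth), compound 3 gives 17% and stands level with compound 1 and compound 2, since all three lie within the usual scatter of one another. Compound 4 `Cc1cc(=O)c2c(O)c(CN3CCC(Cc4ccccc4)CC3)c(O)c([C@H]3CCN(C)C[C@H]3O)c2o1` changes one group of compound 3 (benzyl in place of piperidin-1-yl on a saturated ring carbon) on a saturated ring carbon of a six-membered non-aromatic ring with 1 nitrogen. Going by the values given here, the only measured step (a number 5 percentage points lower from compound 1 to compound 2 (within the scatter)) swaps a different group, so it offers weak guidance and stayed within the scatter. No step beyond the scatter is therefore expected in this assay, and the estimated step (a number 3 percentage points higher from compound 3 to compound 4 (within the scatter)) is small. For compound 4 the estimate is 20% with an expected range from 8% to 36% on this measure.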

Compound 4, percent growth inhibition at one concentration: 16%
Compound 4: middle estimate off by 4 percentage points, on the high side; the measured number falls inside the stated range.
By their numbers in this assay, from the lowest: compounds 4, 3, 2 and 1 (each within the scatter of the next).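

In this assay, putting benzyl in place of piperidin-1-yl on a saturated ring carbon gives a number 1 percentage points lower from compound 3 to compound 4 (within the scatter). At this place, then, a six-membered aromatic ring of carbon only and a six-membered non-aromatic ring holding a nitrogen read alike, something the earlier step, which changed a different group, could not show. Nothing measured here explains this result. Still open, as far as these compounds go, is whether a different kind of group on this ring carbon, such as a carboxylic acid or a primary amine, would shift the number beyond the scatter.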